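The source may report more compounds than this note shows. Statements on the series, on what has been measured and on what is new or still open speak of the compounds shown alone.

Compound 1 `O=C(NCc1ccc(S(=O)(=O)N2CCCCC2)cc1)c1cc2cnccc2s1` and compound 2 `O=C(NCc1ccc(S(=O)(=O)c2ccccc2)cc1)c1cn2ccnc2cn1` have both been run in an ADME assay on microsomes from liver (Mus musculus) for metabolic stability, read by LC-MS, with a stated time of 30 min, tested at 1 uM; on this read-out higher numbers stand for a more stable compound and lower numbers for a less stable compound. Compound 1 gives "below limit of detection" (no number reported) there, so no single number is reported for it. Compound 2 gives 13% in this assay. Compound 3 `O=C(NCc1ccc(S(=O)(=O)N2CCCCC2)cc1)c1cc2ccncc2o1` remains unmeasured. Compound 3 differs from compound 1 in one place: a group of 9 heavy atoms (7 carbon, 1 nitrogen, 1 oxygen; one five-membered aromatic ring with 1 hetero atom, one six-membered aromatic ring with 1 hetero atom) in place of a group of 9 heavy atoms (7 carbon, 1 nitrogen, 1 sulfur; one five-membered aromatic ring with 1 hetero atom, one six-membered aromatic ring with 1 hetero atom), on a carbonyl carbon. Within the data shown here, no step between measured compounds exists to guide the size of this change, so any shift in this assay is expected to be small and not beyond the scatter. Compound 3 is therefore expected to give about 5% in this assay, with a range from 0% to 20%.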

Compound 3, percent of the compound remaining: 0.14%
Compound 3: the middle estimate sits 4.9 percentage points above what was measured, within the range that was stated.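

Among these compounds, compound 1 has no single number in this assay, and no step from it to compound 3 can be read. How far this exchange on the carbonyl carbon shifts the read-out stays open, and nothing shown offers an explanation for the result.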